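Benzyloxy halogen swap on a benzimidazole acylurea series

The compounds below may be only part of what the source reports. "The series", "measured", "known", "first", "only" and "open" are said of these compounds alone.

Of the compounds shown here, three have been tested in a functional assay on MNK45 cells (Homo sapiens) for inhibition, read by MTT assay, with a stated time of 48 h (on this read-out lower numbers stand for stronger inhibition and higher numbers for weaker inhibition), and a fourth awaits its number. Compound 1 `Cc1ccc(NC(=S)NC(=O)c2ccc(OCc3cccc(F)c3)cc2)cc1-c1nc2ccccc2[nH]1` gives 86800 nM. Compound 2 `Cc1ccc(NC(=S)NC(=O)c2ccc(OCc3ccccc3Cl)cc2)cc1-c1nc2ccccc2[nH]1` differs from it by 2-chlorophenyl in place of 3-fluorophenyl on a saturated chain carbon bound to an oxygen on an aromatic ring, and compound 2 gives 51400 nM; the step is a 1.7-fold lower number from compound 1 to compound 2 (0.23 log units; within the scatter). Compound 3 `Cc1ccc(NC(=O)NC(=O)c2ccc(OCc3cccc(F)c3)cc2)cc1-c1nc2ccccc2[nH]1` carries a different core, and the difference between the core of compound 1 and the core of compound 3 is not broken down here. In this assay compound 3 gives 53000 nM. The values of compound 2 and compound 3 lie within the scatter of one another, and the same holds for compound 3 against compound 1, so no order among the three can be read from these numbers.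

Compound 4 `Cc1ccc(NC(=O)NC(=O)c2ccc(OCc3ccccc3Cl)cc2)cc1-c1nc2ccccc2[nH]1` stands to compound 3 as compound 2 stands to compound 1: the change is 2-chlorophenyl in place of 3-fluorophenyl on a saturated chain carbon bound to an oxygen on an aromatic ring, the same change as before, made at the same place. For the measured compounds named here, only one earlier example of this change is available, and it sits within the scatter, so little can be expected of it. Compound 4 is expected to show a 1.4-fold lower number from compound 3 to compound 4 (0.14 log units; within the scatter) because a 1.7-fold lower number from compound 1 to compound 2 (0.23 log units; within the scatter). Compound 4 is therefore estimated at 38000 nM, with the likely range running from 15000 nM to 100000 nM.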

Compound 4, half-maximal inhibitory concentration: 21500 nM
The estimate for compound 4 lay 1.8-fold (0.25 log units) above the measured number; the range from low to high includes it.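

In this assay, 2-chlorophenyl in place of 3-fluorophenyl on the second core gives a 2.5-fold lower number from compound 3 to compound 4 (0.39 log units; beyond the scatter), a modest step. Set beside the earlier step, the change points the same way on both cores, and the two steps do not differ in size: the same change on two cores in this assay, a 1.7-fold lower number (0.23 log units; within the scatter) from compound 1 to compound 2 and a 2.5-fold lower number (0.39 log units; beyond the scatter) from compound 3 to compound 4, 1.5-fold (0.16 log units) apart, within the scatter of two such steps Only the second step lies beyond the scatter, however, so two pairs do not establish that the change will carry over to other cores, and they cannot tell whether the identity of the halogen or its place on the ring accounts for the step, as both change at once.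

The compounds shown leave open how a plain phenyl with no halogen, or a phenyl bearing methoxy or trifluoromethyl, would compare with these two groups on either core. They also leave open whether the same swap would hold on a core carrying an amine or a carboxylic acid, and whether it would hold in cells other than those used here.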